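Moving a methoxy group: compound 1 to compound 4

A few compounds are considered here, and "the series" means these few. Any claim that something is new, unique, unknown or untested is made for them only; others in the source may bear on it.

Measured in a functional assay on COLO 205 cells (Homo sapiens) for inhibition, read by sulforhodamine B assay, with a stated time of 48 h, tested at 50 uM; on this read-out higher numbers stand for more inhibition of growth at the one concentration tested and lower numbers for less inhibition of growth:
- compound 1 `COc1ccccc1/C=C/C(=O)/C=C/c1ccc(OCc2cn(CCCOc3cc(=O)oc4ccccc34)nn2)c(OC)c1` gives 57%
- compound 2 `COc1cc(/C=C/C(=O)/C=C/c2cc(OC)c(OC)c(OC)c2)ccc1OCc1cn(CCCCCOc2cc(=O)oc3ccccc23)nn1` gives 51%
- compound 3 `COc1cccc(/C=C/C(=O)/C=C/c2ccc(OCc3cn(CCCCOc4cc(=O)oc5ccccc45)nn3)c(OC)c2)c1` gives 46%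

Compound 1 has the highest of the three numbers. Compound 2 lies within the usual scatter of it, so the two cannot be told apart; compound 3 sits lower by more than the scatter.

Compound 4 `COc1ccc(/C=C/C(=O)/C=C/c2ccc(OCc3cn(CCCOc4cc(=O)oc5ccccc45)nn3)c(OC)c2)cc1` has the same atoms as compound 1, joined differently: 4-methoxyphenyl in place of 2-methoxyphenyl on a double-bonded chain carbon bound to a double-bonded chain carbon. Among the measured compounds shown here, no pair of measured compounds shows this change, so there is no step to lean on. The expectation is a small move, downward if any, with a number 5 percentage points lower from compound 1 to compound 4 (within the scatter) not beyond the scatter. In this assay compound 4 is therefore expected to give about 52%, with a range from 36% to 68%.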

Compound 4, percent growth inhibition at one concentration: 53%
The estimate for compound 4 lay 1 percentage points below the measured number; measured number inside the range.
By their numbers in this assay, from the lowest: compounds 3, 2, 4 and 1 (each within the scatter of the next, the first and the last beyond it).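

In this assay, putting 4-methoxyphenyl in place of 2-methoxyphenyl on a double-bonded chain carbon bound to a double-bonded chain carbon gives a number 4 percentage points lower from compound 1 to compound 4 (within the scatter). The methoxy group can therefore sit at either of these two ring positions without a change that this read-out can distinguish. Nothing available explains why the two isomers read alike.

Still open, on these data alone, is whether this tolerance extends beyond methoxy, for example to an amine or a carboxylic acid on the same phenyl ring.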